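Methyl to Hydrogen on the Terminal Phenyl Ring

This account rests on a few compounds, and the source may have more. Where it says the series, first, only, none or still open, it means among the compounds named here.

Compound 1 `CN(C)C(=O)c1cc2cnc(Nc3ccc(NC(=O)C4(C(=O)Nc5ccc(F)cc5)CC4)cc3)nc2n1C1CCCC1`: 102%
Compound 2 `Cc1ccc(NC(=O)C2(C(=O)Nc3ccc(Nc4ncc5cc(C(=O)N(C)C)n(C6CCCC6)c5n4)cc3)CC2)cc1`: 90.6%

Of the compounds shown here, two from this series have been measured in a functional assay on A549 cells (Homo sapiens) for inhibition, read by CCK-8 assay, with a stated time of 72 h, tested at 10 uM; a lower number here means less inhibition of growth, a higher number more inhibition of growth at the concentration tested. Compound 1 gives 102%, and compound 2 gives 90.6%. For the measured compounds named here, compound 2 thus stands lowest of the two numbers, with compound 1 as its only neighbour, and the single measured step, a number 11.4 percentage points lower from compound 1 to compound 2 (beyond the scatter), separates them.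

Compound 3 `CN(C)C(=O)c1cc2cnc(Nc3ccc(NC(=O)C4(C(=O)Nc5ccccc5)CC4)cc3)nc2n1C1CCCC1` is the next member. It differs from compound 2 in one place: hydrogen in place of methyl on an aromatic carbon. Going by the values given here, the only measured step that touches this position is the fluoro-to-methyl exchange, which lowered growth inhibition by a number 11.4 percentage points lower from compound 1 to compound 2 (beyond the scatter). Nothing has been measured with hydrogen at that position, so the step to compound 3 is not covered directly. Fluoro gave the higher number and methyl the lower; on the strength of a number 11.4 percentage points lower from compound 1 to compound 2 (beyond the scatter), a modest rise, or a change within the scatter, is expected when methyl gives way to hydrogen. The step is estimated at a number 4.4 percentage points higher from compound 2 to compound 3 (within the scatter). Compound 3 is accordingly estimated at 95%, with a range from 86% to 102%.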

Compound 3, percent growth inhibition at one concentration: 88.8%
Compound 3: the middle estimate sits 6.2 percentage points above what was measured; measured number inside the range.
By their numbers in this assay, from the lowest: compounds 3 and 2 (each within the scatter of the next); then compound 1.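

In this assay, going from 4-methylphenyl to phenyl gives a number 1.8 percentage points lower from compound 2 to compound 3 (within the scatter), so methyl and hydrogen on this aromatic carbon cannot be told apart at the concentration tested. Fluoro now stands apart from both groups, as hydrogen in place of fluoro gives a number 13.2 percentage points lower from compound 1 to compound 3 (beyond the scatter), which adds a second step beyond the scatter to the one already seen with methyl, and of the three compounds only compound 1 differs from the others by more than the scatter. Nothing measured here accounts for this separation of fluoro from methyl and hydrogen.

The compounds shown leave open whether the higher number belongs to fluoro alone or also appears with chloro, trifluoromethyl or methoxy on the same carbon, and whether an amine or a carboxylic acid there would lower the number further. Since all three compounds were read at a single concentration, they also leave open whether the small difference between compound 2 and compound 3, or the larger one separating both from compound 1, would hold across a range of concentrations.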